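Dropping a Fluorine: What Compound 3 Might Show

This account rests on a few compounds, and the source may have more. Where it says the series, first, only, none or still open, it means among the compounds named here.

Measured compounds:
compound 1, `Cc1nn(C)c2nc(NNC(=O)Nc3cc(Cl)nc(Cl)c3)cc(-c3ccc(F)cc3)c12`: 17400 nM
compound 2, `COc1cc(NC(=O)NNc2cc(-c3ccccc3)c3cnn(C)c3n2)cc(Cl)n1`: 28700 nM

Both numbers come from a functional assay on SW620/5-FU cells (Homo sapiens) for cytotoxicity, read by MTT assay, with a stated time of 48 h, in the presence of a further agent that is not named here; on this read-out lower numbers stand for an effect already at smaller amounts and higher numbers for an effect only at larger amounts of compound. Compound 1 gives 17400 nM in this assay, and compound 2 gives 28700 nM. The two values lie within the usual scatter of each other, so neither compound can be set apart from the other on this read-out; compound 1 merely holds the smaller of the two numbers.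

Compound 3, `Cc1nn(C)c2nc(NNC(=O)Nc3cc(Cl)nc(Cl)c3)cc(-c3ccccc3)c12`, has not yet been measured in this assay. It differs from compound 1 in one place: hydrogen in place of fluoro on an aromatic carbon. Going by the values given here, no pair of measured compounds shares this difference, so there is no measured step to lean on. Given how small the change is, no step beyond the scatter is expected, with at most a slight drift toward a higher number. Compound 3 is therefore estimated at 21000 nM, with a range from 8000 nM to 55000 nM. The expected step of a 1.2-fold higher number from compound 1 to compound 3 (0.08 log units; within the scatter) would stay within the scatter.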

Compound 3, half-maximal effective concentration: 22900 nM
Beside the measured number, compound 3's estimate is 1.1-fold (0.04 log units) below it, within the range that was stated.
By their numbers in this assay, from the lowest: compounds 1, 3 and 2 (each within the scatter of the next).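

In this assay, going by these compounds alone, going from 4-fluorophenyl to phenyl gives the first measured step at this position, on an aromatic carbon para to a large group (a 1.3-fold higher number from compound 1 to compound 3 (0.12 log units; within the scatter)). The step stays within the scatter, so the read-out cannot tell these two compounds apart, and removing this one fluorine leaves no measurable mark on the core of compound 1. Nothing available explains this outcome or bears on it.

What the compounds shown leave open is whether this position accepts only the smallest changes, since a single pair cannot show how a methoxy group, an amine or a carboxylic acid at this place would read. On these data alone, whether the same swap would give a similar step on another core also stays open.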